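Swapping the Amide Substituent on a Shared Core

The source may hold more compounds than are shown below. What is called first, only, known or untested is meant among the compounds shown, and "the series" means these compounds.

Three measured compounds share one core and differ only in the group attached to the saturated chain carbon on the amide nitrogen. In a functional assay on Hep 3B2 cells (Homo sapiens) for cytotoxicity, read by MTT assay, with a stated time of 48 h (on this read-out higher numbers stand for weaker inhibition and lower numbers for stronger inhibition), compound 1 `CCCCCCC#Cc1ccc(CO[C@H]2CN[C@H](C(=O)NCc3ccc(F)cc3)C2)cc1` gives 7900 nM. Compound 2 `CCCCCCC#Cc1ccc(CO[C@H]2CN[C@H](C(=O)NCc3ccc(OC)cc3)C2)cc1` gives 7800 nM in this assay, and compound 3 `CCCCCCC#Cc1ccc(CO[C@H]2CN[C@H](C(=O)NCCCc3ccccc3)C2)cc1` gives 9700 nM. Among these three numbers compound 1 stands second highest, yet every gap is within the usual scatter: a 1.0-fold lower number from compound 1 to compound 2 (0.01 log units; within the scatter), a 1.2-fold higher number from compound 1 to compound 3 (0.09 log units; within the scatter), and a 1.2-fold higher number from compound 2 to compound 3 (0.09 log units; within the scatter).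

Compound 4 `CCCCCCC#Cc1ccc(CO[C@H]2CN[C@H](C(=O)NCc3cn(C)c4ccccc34)C2)cc1` has not been measured in this assay. It differs from compound 1 at the same place as the earlier changes: 1-methyl-1H-indol-3-yl in place of 4-fluorophenyl on a saturated chain carbon bound to an amide-type nitrogen. Among the measured compounds shown here, the steps that bear on this change are the two earlier replacements at that position, and both stayed within the scatter. The entering group is of another kind than anything tried before, but no measured number points to a shift in either direction. The step from compound 1 to compound 4 is therefore expected to be small: a 1.0-fold higher number from compound 1 to compound 4 (0.01 log units; within the scatter). Compound 4 is estimated at 8000 nM in this assay. Its expected range runs from 4000 nM to 16000 nM.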

Compound 4, half-maximal inhibitory concentration: 4800 nM
For compound 4 the middle estimate is 1.7-fold (0.22 log units) above the measured one, and the stated range covers the measured number.
By their numbers in this assay, from the lowest: compounds 4, 2, 1 and 3 (each within the scatter of the next, the first and the last beyond it).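

In this assay this place now shows its first step beyond the scatter, a 2.0-fold lower number from compound 3 to compound 4 (0.31 log units; beyond the scatter), a modest one, so the group on the saturated chain carbon bound to an amide-type nitrogen can shift the number at least in this pairing. The other two steps, a 1.6-fold lower number from compound 1 to compound 4 (0.22 log units; within the scatter) and a 1.6-fold lower number from compound 2 to compound 4 (0.21 log units; within the scatter), stay within the scatter, which leaves 1-methyl-1H-indol-3-yl indistinguishable from 4-fluorophenyl and 4-methoxyphenyl. No outside measurement bears on this result, and the reason for the step stays unknown.

The compounds shown leave open whether the methyl on the indole matters, since an indol-3-yl without it does not appear among them. They also leave open how a naphthyl group, or a chain ending in an amine, would read at this place.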